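Compound 4 and a group removed from a silent analogue

The source may hold more compounds than are shown below. What is called first, only, known or untested is meant among the compounds shown, and "the series" means these compounds.

Measured in a functional assay on 4T1 cells (Mus musculus) for antiproliferative activity, read by MTT assay, with a stated time of 48 h; on this read-out lower numbers stand for stronger inhibition and higher numbers for weaker inhibition:
- Compound 1 `COC1=CC(=O)N(C(=O)/C=C/[C@H](C)NC(=O)[C@H](CC(C)C)N(C)C)[C@H]1Cc1ccccc1`: > 100000 nM
- Compound 2 `COC1=CC(=O)N(C(=O)/C=C/[C@H](C)NC(=O)[C@H](CC(C)C)N(C)C)[C@@H]1Cc1ccccc1`: > 100000 nM
- Compound 3 `CC[C@H](C)[C@H](NC(=O)OCc1ccccc1)C(=O)N[C@@H](CC(C)C)C(=O)N[C@@H](CC(C)C)C(=O)N[C@@H](C)/C=C/C(=O)N1C(=O)C=C(OC)[C@@H]1c1cn(C(=O)OC(C)(C)C)c2ccccc12`: > 100000 nM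

All the data shown here rest on (the limit of > 100000 nM in this assay, at which 3 of the 3 values shown sit), so none of the three entries is a number. Compound 3 gives > 100000 nM, which is a limit of the assay. Its two companions are limits as well, so compound 3 cannot be ranked against either of them.

The next compound, compound 4 `CC[C@H](C)[C@H](NC(=O)OCc1ccccc1)C(=O)N[C@@H](CC(C)C)C(=O)N[C@@H](CC(C)C)C(=O)N[C@@H](C)/C=C/C(=O)N1C(=O)C=C(OC)[C@@H]1c1c[nH]c2ccccc12`, differs from compound 3 at one place: hydrogen in place of tert-butoxycarbonyl on an aromatic nitrogen. Hydrogen thus stands in place of tert-butoxycarbonyl on an aromatic nitrogen.

For the measured compounds named here, only one measured step exists, a step that the two limits leave unreadable from compound 1 to compound 2, and it reflects (the fact that compounds 1 and 2 differ only in the configuration as drawn). It does not touch this group and gives no size to carry over, so the data offer no direct guide to the change. Since a limit is all that is known for compound 3, only a cautious expectation is possible: a modest move towards stronger inhibition, or none that can be read. The expected result is an at least 1.6-fold lower number from compound 3 to compound 4 (0.22 log units; that floor lies within the scatter). For compound 4 the estimated value is 60000 nM, with an expected range from 10000 nM to 200000 nM.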

Compound 4, half-maximal inhibitory concentration: > 100000 nM
Compound 4: only a limit was reported; the forecaster's own chance of this, stated with the estimate: 60%; at least 1.6-fold (0.22 log units) between middle value and limit.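

In this assay compound 4 gives > 100000 nM, which is a limit of the assay. For the compounds shown here, compound 3 also stands at a limit, so no step from compound 3 to compound 4 can be read. The compounds shown leave open whether hydrogen in place of tert-butoxycarbonyl alters inhibition at all, because every entry is a limit: the limit of > 100000 nM in this assay, at which 4 of the 4 values shown sit.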